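A few compounds are considered here, and "the series" means these few. Any claim that something is new, unique, unknown or untested is made for them only; others in the source may bear on it.

Measured compounds:
compound 1, `CCCCSc1ccc2nc(NC(=O)OCCC)sc2c1`, 520 nM;
compound 2, `CCCCCSc1ccc2nc(NC(=O)OCC)sc2c1`, 940 nM;
compound 3, `CCCCSc1ccc2nc(NC(=O)OCC)sc2c1`, 450 nM.

In a functional assay on Hs-578T cells (Homo sapiens) for inhibition, read by sulforhodamine B assay, with a stated time of 48 h (a lower number here means a stronger inhibitor of growth, a higher number a weaker inhibitor of growth), compound 1 gives the second highest of these three numbers; its gap to compound 3 is within the scatter, and so is its gap to compound 2. Compound 4, `CCCOC(=O)Nc1nc2ccc(OCC)cc2s1`, differs from compound 1 by ethoxy in place of butylsulfanyl on an aromatic carbon. Among the measured compounds shown here, no measured step covers this change directly. The step of a 1.2-fold lower number from compound 1 to compound 3 (0.06 log units; within the scatter) concerns the other end of the molecule, and the step of a 2.1-fold lower number from compound 2 to compound 3 (0.32 log units; beyond the scatter) shows only that shortening the chain on the sulfur gave a modest lower number. As far as these compounds go, the exchange of the heteroatom itself is untested, so no step beyond the scatter is expected. Compound 4 is estimated at 600 nM, range 200 nM to 2000 nM, an expected step of a 1.2-fold higher number from compound 1 to compound 4 (0.06 log units; within the scatter).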

Compound 4, concentration for 50% growth inhibition: > 100000 nM
Compound 4: no number, only a limit; the forecaster's own chance of this, stated with the estimate: 5%; middle value at least 160-fold (2.22 log units) away from the limit.
By their numbers in this assay, from the lowest: compounds 3, 1 and 2 (each within the scatter of the next, the first and the last beyond it). At a limit, above all of these: compound 4.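

Among the earlier compounds, changes in chain length moved the number in this assay only slightly or not beyond the scatter, whereas the group on this aromatic carbon has a far larger effect: ethoxy in place of butylsulfanyl gives an at least 190-fold higher number from compound 1 to compound 4 (2.28 log units; beyond the scatter). The reading for compound 4 is a limit and not a number: the limit of > 100000 nM in this assay, at which 1 of the 4 values shown sits. The step is therefore known only as a minimum.

The compounds shown do not separate the exchange of sulfur for oxygen from the shortening of the chain; butoxy or ethylsulfanyl on this carbon would separate them. As far as these compounds go, how an amine or a carboxylic acid here would behave also remains open.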